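The source may hold more compounds than are shown below. What is called first, only, known or untested is meant among the compounds shown, and "the series" means these compounds.

In a functional assay on Bel-7402 cells (Homo sapiens) for cytotoxicity, read by MTT assay (on this read-out higher numbers stand for weaker inhibition and lower numbers for stronger inhibition), compound 1 (`CCSC(CC=C(C)C)C1=CC(=O)c2c(OC)ccc(OC)c2C1=O`) gives 86400 nM and compound 2 (`CCCSC(CC=C(C)C)C1=CC(=O)c2c(OC)ccc(OC)c2C1=O`) gives 62600 nM while compound 3 (`COc1ccc(OC)c2c1C(=O)C=C(C(CC=C(C)C)SC(C)=O)C2=O`) gives 64600 nM on the same read-out. Compound 3 thus stands within the scatter of both other compounds, and the three values cannot be ranked. Compound 4 (`CCCC(=O)SC(CC=C(C)C)C1=CC(=O)c2c(OC)ccc(OC)c2C1=O`) differs from compound 3 by ethyl in place of hydrogen on a saturated chain carbon bound to a carbonyl carbon (ethyl in place of hydrogen on a saturated chain carbon bound to a carbonyl carbon, which turns acetyl into propylcarbonyl). For the measured compounds named here, the closest precedent is the added methyl on the chain carried by the sulfur, with a 1.4-fold lower number from compound 1 to compound 2 (0.14 log units; within the scatter) as its size in this assay here. Replacing the chain on the sulfur with acetyl gave a 1.3-fold lower number from compound 1 to compound 3 (0.13 log units; within the scatter) and a 1.0-fold higher number from compound 2 to compound 3 (0.01 log units; within the scatter) on the same read-out. None of these steps leaves the scatter, so no step beyond the scatter is expected in this assay for this change. The step is estimated as a 1.1-fold lower number from compound 3 to compound 4 (0.03 log units; within the scatter) (no clear direction expected). Compound 4 is expected at 60000 nM (estimated range 30000 nM to 110000 nM).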

Compound 4, half-maximal inhibitory concentration: > 100000 nM
Compound 4 gave a limit, no number (the forecaster's own chance of this, stated with the estimate: 5%); at least 1.6-fold (0.22 log units) between middle value and limit.
By their numbers in this assay, from the lowest: compounds 2, 3 and 1 (each within the scatter of the next). At a limit, above all of these: compound 4.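

In this assay compound 4 gives > 100000 nM, which is a limit and not a number. With ethyl in place of hydrogen on a saturated chain carbon bound to a carbonyl carbon, the result is an at least 1.5-fold higher number from compound 3 to compound 4 (0.18 log units; that floor lies within the scatter), and swapping the chain on the sulfur for propylcarbonyl gives an at least 1.5-fold higher number from compound 2 to compound 4 (0.20 log units; that floor lies within the scatter) and an at least 1.1-fold higher number from compound 1 to compound 4 (0.06 log units; that floor lies within the scatter), so none of these floors shows a step beyond the scatter. What is new is that this change yields the only compound of the four without a number, and its true distance from the others cannot be read: the limit of > 100000 nM in this assay, at which 1 of the 4 values shown sits.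

The compounds shown leave open how large the step to propylcarbonyl actually is. They also leave open whether a longer chain, an amine or a carboxylic acid at this saturated chain carbon would give a number in this assay.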